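Amino for Hydroxy on a Triple-Bonded Nucleoside Series

The compounds below may be only part of what the source reports. "The series", "measured", "known", "first", "only" and "open" are said of these compounds alone.

Of the compounds shown here, three have been measured, all on the same nucleoside core. Compound 1 `CCCC#Cc1cn([C@@H]2O[C@H](CO)[C@@H](O)[C@H](O)[C@H]2O)c(=O)nc1N` and compound 2 `CCCCCC#Cc1cn([C@@H]2O[C@H](CO)[C@@H](O)[C@H](O)[C@H]2O)c(=O)nc1N` differ only in the length of the chain on the triple bond, while compound 3 `CC(C)(C)c1ccc(C#Cc2cn([C@@H]3O[C@H](CO)[C@@H](O)[C@H](O)[C@H]3O)c(=O)nc2O)cc1` carries a tert-butylphenyl group on the triple bond and a hydroxy in place of the amino of the first two. In a functional assay on CCRF-CEM cells (Homo sapiens) for cytotoxicity, with a stated time of 72 h (a lower number here means a stronger inhibitor, a higher number a weaker inhibitor), compound 1 gives only a limit, > 250000 nM. In this assay compound 2 likewise gives only a limit, > 250000 nM. Compound 3 in this assay also gives only a limit, > 250000 nM. Among the compounds with values here, the one measured step, a step that the two limits leave unreadable from compound 1 to compound 2, cannot be read in size or direction, as the limit of > 250000 nM in this assay, at which 3 of the 3 values shown sit, describes. Compound 4 `CC(C)(C)c1ccc(C#Cc2cn([C@@H]3O[C@H](CO)[C@@H](O)[C@H](O)[C@H]3O)c(=O)nc2N)cc1` differs from compound 3 by amino in place of hydroxy on an aromatic carbon. Within the data shown here, no measured step bears on this exchange, and no readable step exists at all; the only thing known is that compound 3 sits at the limit of this assay. The expected step of a number no higher from compound 3 to compound 4 (the limit leaves the size open) is therefore none beyond the scatter, and most likely another limit. Compound 4 is estimated to give 250000 nM in this assay, with a range from 50000 nM to 1000000 nM.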

Compound 4, half-maximal inhibitory concentration: > 250000 nM
Compound 4 was reported as a limit; the forecaster's own chance of this, stated with the estimate: 80%; the middle value sits exactly at the limit.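

Compound 4 gives only a limit in this assay, so no step from compound 1, compound 2 or compound 3 to compound 4 can be read: the limit of > 250000 nM in this assay, at which 4 of the 4 values shown sit.

The compounds shown leave open what amino in place of hydroxy, or a different group on the triple bond, does in this assay, and whether any compound on this core gives a number rather than a limit.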